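The source may report more compounds than this note shows. Statements on the series, on what has been measured and on what is new or still open speak of the compounds shown alone.

Measured compounds in a functional assay on HEK293 cells for antagonist activity at P2X purinoceptor 7 (Homo sapiens); on this read-out lower numbers stand for stronger inhibition and higher numbers for weaker inhibition:
compound 1 `CN1C(=O)C(C)(C)C[C@H]1C(=O)NCc1cccc(C(F)(F)F)c1Cl` gives 25.1 nM
compound 2 `CN1C(=O)C(F)(F)C[C@H]1C(=O)NCc1cccc(C(F)(F)F)c1Cl` gives 3.98 nM
compound 3 `CN1CCC(N2C[C@@H](C(=O)NCc3cccc(C(F)(F)F)c3Cl)N(C)C2=O)CC1` gives 31.6 nM

Among these three, compound 3 gives the highest number in this assay. Its value and that of compound 1 lie within the usual scatter of one another, so the two cannot be told apart on this read-out. Compound 2, on the other hand, gives a clearly lower number than compound 3, and that gap lies beyond the scatter. All three share the same amide and the same substituted benzyl group; they differ only in the ring that carries the methylated amide nitrogen and in what sits on it.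

Compound 4 `Cc1ncccc1N1C[C@@H](C(=O)NCc2cccc(C(F)(F)F)c2Cl)N(C)C1=O` keeps the core of compound 3 and changes only the group on the ring nitrogen: 2-methylpyridin-3-yl in place of 1-methylpiperidin-4-yl on an amide-type nitrogen in a ring. For the measured compounds named here, no measured pair in this set shows this kind of exchange, so there is no step to lean on. The estimate rests only on compound 3 itself. Compound 4 is expected to give 20 nM, with a range from 5 nM to 80 nM. This estimate means a step of a 1.6-fold lower number from compound 3 to compound 4 (0.20 log units; within the scatter), which is expected to stay within the scatter rather than mark a real change in either direction.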

Compound 4, half-maximal inhibitory concentration: 5.01 nM
For compound 4 the middle estimate is 4.0-fold (0.60 log units) above the measured one; low and high end bracket the measured number.
By their numbers in this assay, from the lowest: compounds 2 and 4 (each within the scatter of the next); then compounds 1 and 3 (each within the scatter of the next).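

In this assay, putting 2-methylpyridin-3-yl in place of 1-methylpiperidin-4-yl on the amide-type nitrogen in a ring gives a 6.3-fold lower number from compound 3 to compound 4 (0.80 log units; beyond the scatter), which shows that this position responds to the group it carries. The two groups match in heavy-atom count, in hydrogen-bond donors and acceptors, and in net charge, so the step comes with a change those counts do not capture: a non-aromatic ring gives way to an aromatic one, and the attachment and substitution of the ring differ as well. Nothing in the data at hand gives a reason for this step.

Because the exchange alters the ring and its methyl group together, the compounds shown leave open whether the aromatic ring alone goes with the lower number or whether the methyl group also contributes, a question that an unsubstituted pyridin-3-yl or a phenyl group on the same nitrogen would address. They also leave open whether a piperidin-4-yl group without its methyl group would stay close to compound 3 or move towards compound 4.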